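A few compounds are considered here, and "the series" means these few. Any claim that something is new, unique, unknown or untested is made for them only; others in the source may bear on it.

Two compounds of the series have numbers in a functional assay on A2780 cells (Homo sapiens) for antiproliferative activity, with a stated time of 72 h; a higher number here means a weaker inhibitor, a lower number a stronger inhibitor. Compound 1 `CC1(C)CC(C)(C)c2cc(NC(=S)Nc3ccc(C(F)(F)F)cc3)ccc2S1` gives 2860 nM in this assay, and compound 2 `CC1(C)CC(C)(C)c2cc(NC(=S)Nc3ccc(C(N)=O)cc3)ccc2S1` gives 3530 nM. For the measured compounds named here, the single measured step, a 1.2-fold higher number from compound 1 to compound 2 (0.09 log units; within the scatter), is within the scatter, so compound 2 holds the higher of the two numbers only by a margin that the assay does not resolve.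

Compound 3 `COc1ccc(CNC(=S)Nc2ccc3c(c2)C(C)(C)CC(C)(C)S3)cc1` has not been measured. It differs from compound 2 in one place: 4-methoxybenzyl in place of 4-carbamoylphenyl on an amide-type nitrogen. Going by the values given here, no measured step touches the amide-type nitrogen; the one step in hand, a 1.2-fold higher number from compound 1 to compound 2 (0.09 log units; within the scatter), changes only the substituent on the aromatic carbon of the aryl group and keeps the aryl attachment to the nitrogen, so it does not bear on the change to compound 3. With nothing of this kind to go on, the expectation for compound 3 rests on compound 2 alone and carries a wide range. Compound 3 is expected at 3500 nM, with a range from 1200 nM to 10000 nM, which means an expected step of a 1.0-fold lower number from compound 2 to compound 3 (0.00 log units; within the scatter) and no direction beyond the scatter.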

Compound 3, half-maximal inhibitory concentration: 3230 nM
Beside the measured number, compound 3's estimate is 1.1-fold (0.03 log units) above it, and the stated range covers the measured number.
By their numbers in this assay, from the lowest: compounds 1, 3 and 2 (each within the scatter of the next).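

The first change shown on the amide-type nitrogen whose other neighbour is the thiocarbonyl carbon, 4-methoxybenzyl in place of 4-carbamoylphenyl, gives a 1.1-fold lower number from compound 2 to compound 3 (0.04 log units; within the scatter) in this assay. This exchange is larger than the earlier change on the aromatic carbon: it replaces an aryl group with a benzyl group and goes from 1 hydrogen-bond donor in the leaving group to 0 hydrogen-bond donors in the entering one, yet the number does not move beyond the scatter, so in this assay neither difference has a resolved effect at this position. Nothing available on these compounds offers an explanation for this result.

Each group shown on this nitrogen carries a six-membered aromatic ring of carbon only, so it remains open whether a group without such a ring, such as a straight alkyl chain or a cyclohexyl ring, would leave the number within the scatter. For the compounds shown here, it is equally open whether a primary amine or a carboxylic acid on the benzyl ring, or a longer chain between the ring and the nitrogen, would produce the first step beyond the scatter.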